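Replacing a Carboxypyrrolidine Amide with a Sulfamoylphenyl Ring

The source may hold more compounds than are shown below. What is called first, only, known or untested is meant among the compounds shown, and "the series" means these compounds.

Compound 1 `N=C(N)c1cccc(OCC(=O)Nc2ccc(C(=O)N3CCC3)cc2)c1` gives 2050 nM in an assay on isolated protein for inhibition of serine protease 1 (Homo sapiens); on this read-out lower numbers stand for stronger inhibition and higher numbers for weaker inhibition.
Compound 2 `N=C(N)c1cccc(OCC(=O)Nc2ccc(C(=O)N3CCCC3)cc2)c1` gives 2700 nM in this assay.
Compound 3 `N=C(N)c1cccc(OCC(=O)Nc2ccc(C(=O)N3CCCC3C(=O)O)cc2)c1` gives > 10000 nM in this assay, which is a limit, not a number.

Compound 3 thus sits at the limit of > 10000 nM in this assay, at which 1 of the 3 values shown sits, and shows weaker inhibition than both other compounds, since an at least 4.8-fold higher number from compound 1 to compound 3 (0.68 log units; beyond the scatter) and an at least 3.7-fold higher number from compound 2 to compound 3 (0.56 log units; beyond the scatter).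

The step to compound 4 `N=C(N)c1cccc(OCC(=O)Nc2ccc(-c3ccccc3S(N)(=O)=O)cc2)c1` is 2-sulfamoylphenyl in place of (2-carboxypyrrolidin-1-yl)carbonyl on an aromatic carbon. Going by the values given here, two measured steps bear on it. Among the compounds with values here, the carboxy group that enters in the step from compound 2 to compound 3 is the one part of compound 3 that is clearly tied to its loss of potency, and compound 4 no longer carries it. Whether the sulfamoylphenyl ring itself helps or hurts cannot be read from any measured pair, as no compound shown carries it. The expected change is therefore a gain of about the size lost on adding the carboxy group, an at least 4.0-fold lower number from compound 3 to compound 4 (0.60 log units; beyond the scatter), back into the range of compound 1 and compound 2. Compound 4 is estimated at 2500 nM, most likely between 500 nM and 10000 nM.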

Compound 4, half-maximal inhibitory concentration: 3370 nM
Compound 4: middle estimate off by 1.3-fold (0.13 log units), on the low side, within the range that was stated.
By their numbers in this assay, from the lowest: compounds 1, 2 and 4 (each within the scatter of the next). At a limit, above all of these: compound 3.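

Replacing (2-carboxypyrrolidin-1-yl)carbonyl with 2-sulfamoylphenyl on this aromatic carbon, para to a large group, improves the read-out in this assay, with an at least 2.9-fold lower number from compound 3 to compound 4 (0.47 log units; beyond the scatter). This position also accepts two quite different groups with no clear change in the read-out: the comparison with the simple amides gives a 1.2-fold higher number from compound 2 to compound 4 (0.10 log units; within the scatter) and a 1.6-fold higher number from compound 1 to compound 4 (0.22 log units; within the scatter), so compound 4 cannot be told apart from either. The gain over compound 3 can be given only as a bound, because the value of compound 3 is a limit, not a number: the limit of > 10000 nM in this assay, at which 1 of the 4 values shown sits.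

Going by these compounds, what the sulfamoyl group adds beyond the phenyl ring that carries it remains open, and an unsubstituted phenyl would help to separate the two. On these data alone, it is also open whether a methylsulfonyl group or a carboxylic acid on that phenyl ring would change the read-out.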